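Swapping a Tetrazole Thioether for a Phenylpiperazine

This account rests on a few compounds, and the source may have more. Where it says the series, first, only, none or still open, it means among the compounds named here.

Compound 3 `Cn1nnnc1SCC(=O)Nc1ccc(-c2nc(-c3ccccc3)c(-c3ccccc3)n2C)cc1` is the strongest of the three measured compounds in a functional assay on MCF7 cells (Homo sapiens) for cytotoxicity, read by MTT assay, with a stated time of 24 h, tested at 6.4 ug/mL; on this read-out higher numbers stand for a stronger effect at the one concentration tested and lower numbers for a weaker effect: compound 3 gives 55.9%. Compound 1 `Cn1c(-c2ccc(NC(=O)CSc3nc4ccccc4o3)cc2)nc(-c2ccccc2)c1-c1ccccc1` gives 42.3%, and compound 2 `Cc1ccc2oc(SCC(=O)Nc3ccc(-c4nc(-c5ccccc5)c(-c5ccccc5)n4C)cc3)nc2c1` gives 24.6%. Both measured steps toward compound 3 ran upward, a number 13.6 percentage points higher from compound 1 to compound 3 (beyond the scatter) and a number 31.3 percentage points higher from compound 2 to compound 3 (beyond the scatter), and each of them only exchanged the ring on the sulfur. Compound 4 `Cn1c(-c2ccc(NC(=O)CN3CCN(c4ccccc4)CC3)cc2)nc(-c2ccccc2)c1-c1ccccc1` alters something different: 4-phenylpiperazin-1-yl in place of (1-methyl-1H-tetrazol-5-yl)sulfanyl on a saturated chain carbon bound to a carbonyl carbon, so the sulfur leaves together with its ring. Going by the values given here, no measured step covers a change of this kind, so its direction is open; since every measured value lies in a middle band, a modest downward step is expected, a number 15.9 percentage points lower from compound 3 to compound 4 (beyond the scatter). Compound 4 is therefore estimated at 40%, within a range from 15% to 65%.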

Compound 4, a percentage reported as activity, at one concentration (the size of the read-out at that concentration, not a potency): 37.7%
Estimate against measurement, compound 4: 2.3 percentage points above, and the stated range covers the measured number.
By their numbers in this assay, from the lowest: compound 2; then compounds 4 and 1 (each within the scatter of the next); then compound 3.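

On the saturated chain carbon bound to a carbonyl carbon, the sulfur and its ring can be replaced together, and the outcome depends on which group leaves. In this assay, 4-phenylpiperazin-1-yl gives a number 18.2 percentage points lower from compound 3 to compound 4 (beyond the scatter) and a number 13.1 percentage points higher from compound 2 to compound 4 (beyond the scatter) but a number 4.6 percentage points lower from compound 1 to compound 4 (within the scatter) when it replaces (1,3-benzoxazol-2-yl)sulfanyl. Nothing available accounts for these steps. From the compounds shown here alone, what a morpholin-4-yl or a diethylamino group would do on this carbon remains open. So does how much of the result belongs to the phenyl on the piperazine.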